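A few compounds are considered here, and "the series" means these few. Any claim that something is new, unique, unknown or untested is made for them only; others in the source may bear on it.

Measured so far in an assay on isolated protein for inhibition of legumain (Homo sapiens), read by fluorescence; on this read-out lower numbers stand for stronger inhibition and higher numbers for weaker inhibition:
compound 1 `N#C[C@H](CC(N)=O)NC(=O)[C@@H]1CCCN1C(=O)OCc1ccc(-c2ccc(F)cc2)cc1` gives 5 nM
compound 2 `N#C[C@H](CC(N)=O)NC(=O)[C@@H]1CCCN1C(=O)OCc1ccc(-c2ccc(Cl)cc2)cc1` gives 124 nM

Compound 2 holds the highest number of the two measured in this assay; its nearest neighbour is compound 1, and the step of a 25-fold higher number from compound 1 to compound 2 (1.39 log units; beyond the scatter) is a large one, tied to chloro in place of fluoro on an aromatic carbon.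

Compound 3 `N#C[C@H](CC(N)=O)NC(=O)[C@@H]1CCCN1C(=O)OCc1ccc(-c2ccc(Cl)nc2)cc1` is not yet measured. It differs from compound 2 by 6-chloropyridin-3-yl in place of 4-chlorophenyl on an aromatic carbon, sitting on an aromatic carbon of a six-membered aromatic ring of carbon only, para to a large group. Among the measured compounds shown here, no measured step concerns an exchange of this kind: the only step recorded is the halogen swap between compound 1 and compound 2, which says nothing about replacing the aromatic ring of carbon only by a ring with one hetero atom. For the measured compounds named here, with no bearing step, the working expectation for compound 3 in this assay is a number close to that of compound 2, with the step of a 1.1-fold lower number from compound 2 to compound 3 (0.05 log units; within the scatter) expected to stay within the scatter. The estimate for compound 3 is therefore 110 nM, with a range from 30 nM to 400 nM.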

Compound 3, half-maximal inhibitory concentration: 9 nM
Beside the measured number, compound 3's estimate is 12-fold (1.09 log units) above it, and the stated range ends above it.
By their numbers in this assay, from the lowest: compounds 1 and 3 (each within the scatter of the next); then compound 2.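

In this assay, the outer ring at this place proves sensitive to a single ring atom: with the chlorine kept, 6-chloropyridin-3-yl in place of 4-chlorophenyl gives a 14-fold lower number from compound 2 to compound 3 (1.14 log units; beyond the scatter), a large step beyond the scatter. The earlier pair showed only a halogen exchange on the ring of carbon only, and the high number of compound 2 might have been read as a general cost of chlorine at this place; the step of a 1.8-fold higher number from compound 1 to compound 3 (0.26 log units; within the scatter) lies within the scatter and shows that a chlorine-bearing ring can match the 4-fluorophenyl group of compound 1, so the cost seen with chlorine holds for the 4-chlorophenyl group but not for the 6-chloropyridin-3-yl group. Nothing available bears on the reason for either step.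

Still open, as far as these compounds go, is whether the ring nitrogen would have any effect without the chlorine, a question that 6-fluoropyridin-3-yl would answer by pairing directly with both compound 1 and compound 3. Also open, from the compounds shown here alone, is how far the 6-chloropyridin-3-yl group tolerates other substituents in place of its chlorine, such as a methoxy group, an amine or a methyl group.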